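The source may report more compounds than this note shows. Statements on the series, on what has been measured and on what is new or still open speak of the compounds shown alone.

Measured so far in a functional assay on PANC-1 cells (Homo sapiens), read by microscopy, crystal violet staining and transwell migration, with a stated time of 18 h, in the presence of a further agent that is not named here; on this read-out higher numbers stand for weaker inhibition and lower numbers for stronger inhibition:
- compound 1 `CCc1nc(-c2ccc(OC)cn2)n(-c2cccc(C(=O)NCCCCc3ccccc3)c2)n1` gives 120 nM
- compound 2 `CCc1nc(-c2ncc(OC)cn2)n(-c2cccc(C(=O)NCCCCc3ccccc3)c2)n1` gives 110 nM

Compound 2 cannot be told apart from compound 1, since their two numbers lie within the usual scatter of each other. The next compound, compound 3 `CCc1nc(-c2ccc(O)cc2)n(-c2cccc(C(=O)NCCCCc3ccccc3)c2)n1`, puts 4-hydroxyphenyl in place of 5-methoxypyrimidin-2-yl on the shared core (4-hydroxyphenyl in place of 5-methoxypyrimidin-2-yl on an aromatic carbon). Within the data shown here, only one measured step bears on this change (a 1.1-fold lower number from compound 1 to compound 2 (0.04 log units; within the scatter)). It exchanged one methoxy-bearing ring for another and stayed within the scatter. Among the measured compounds shown here, the new change is larger, since the entering group has a hydrogen-bond donor and the leaving group has none, and no measured compound shows what such a swap does here. No direction can be argued, so no step beyond the scatter is expected (a 1.2-fold higher number from compound 2 to compound 3 (0.07 log units; within the scatter)), though with wide uncertainty. Compound 3 is estimated at 130 nM (range 35 nM to 500 nM).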

Compound 3, half-maximal inhibitory concentration: 220 nM
For compound 3 the middle estimate is 1.7-fold (0.23 log units) below the measured one; low and high end bracket the measured number.
By their numbers in this assay, from the lowest: compounds 2, 1 and 3 (each within the scatter of the next).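

In this assay, this position on the aromatic carbon of the shared core accepts a ring of carbon only, bearing a hydrogen-bond donor, in place of either ring containing nitrogen and a methoxy group, with both new steps inside the usual scatter (a 2.0-fold higher number from compound 2 to compound 3 (0.30 log units; within the scatter); a 1.8-fold higher number from compound 1 to compound 3 (0.26 log units; within the scatter)). So the earlier finding that two closely related methoxy-bearing rings cannot be told apart now extends to a less similar ring, 4-hydroxyphenyl. No measurement available here explains why these numbers fall so close together.

Still open, going by these compounds, is whether this range holds for rings carrying other groups, such as 4-aminophenyl or 4-carboxyphenyl. It is also unknown what happens with no ring at this position, for instance with a simple methyl group.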